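Dechlorination in a Second Triazole Series

The compounds below may be only part of what the source reports. "The series", "measured", "known", "first", "only" and "open" are said of these compounds alone.

Compound 1 `CCN(CC)CCn1cnnc1-c1cc(Oc2ccc(NC(=O)Nc3ccc(Cl)c(C(F)(F)F)c3)cc2F)ccn1` and compound 2 `CCN(CC)CCn1cnnc1-c1cc(Oc2ccc(NC(=O)Nc3cccc(C(F)(F)F)c3)cc2F)ccn1` share one core and differ only in one place: hydrogen in place of chloro on an aromatic carbon. In a functional assay on NCI-H460 cells (Homo sapiens) for antiproliferative activity, read by MTT assay, with a stated time of 72 h (a lower number here means a stronger inhibitor, a higher number a weaker inhibitor), compound 1 gives 850 nM, and compound 2 gives 9870 nM, so the change costs a 12-fold higher number from compound 1 to compound 2 (1.06 log units; beyond the scatter).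

Compound 3 `CN(C)CCCn1cnnc1-c1cc(Oc2ccc(NC(=O)Nc3ccc(Cl)c(C(F)(F)F)c3)cc2F)ccn1` carries the same aryl urea as compound 1 on a different core; the two cores differ in this way: (dimethylamino)methyl in place of diethylamino on a saturated chain carbon, two bonds along the chain from an aromatic nitrogen. In this assay compound 3 gives 1680 nM, which is a 2.0-fold higher number from compound 1 to compound 3 (0.30 log units; within the scatter) and therefore tells nothing against the two cores being close in activity.

Compound 4 `CN(C)CCCn1cnnc1-c1cc(Oc2ccc(NC(=O)Nc3cccc(C(F)(F)F)c3)cc2F)ccn1` is not yet measured. It stands to compound 3 as compound 2 stands to compound 1: hydrogen in place of chloro on an aromatic carbon. The place of the change is described in the same words in both pairs, so this is the same change, made on a core that so far behaves much like the core of compound 1. For the measured compounds named here, the one measured instance of the change is large and well beyond the scatter, and nothing among the measured compounds suggests the second core would soften it. The writer therefore expects a step of about an 11-fold higher number from compound 3 to compound 4 (1.03 log units; beyond the scatter) from compound 3 to compound 4, resting on the step from compound 1 to compound 2 and on compound 3 giving 1680 nM. Compound 4 is accordingly estimated to give about 18000 nM in this assay, with a plausible range from 7000 nM to 45000 nM, the width allowing for only one prior observation of this change.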

Compound 4, half-maximal inhibitory concentration: 1790 nM
For compound 4 the middle estimate is 10-fold (1.00 log units) above the measured one; the whole stated range lies above it.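

In this assay, hydrogen in place of chloro on the core of compound 3 gives a 1.1-fold higher number from compound 3 to compound 4 (0.03 log units; within the scatter), so the large cost seen on the core of compound 1 does not carry over to this second core: the same change on two cores in this assay, a 12-fold higher number (1.06 log units; beyond the scatter) from compound 1 to compound 2 and a 1.1-fold higher number (0.03 log units; within the scatter) from compound 3 to compound 4, 11-fold (1.04 log units) apart, beyond the scatter of two such steps. The same disagreement appears when the aryl urea is held fixed and the amine side chain is changed, as the 3-(trifluoromethyl)phenyl pair gives a 5.5-fold lower number from compound 2 to compound 4 (0.74 log units; beyond the scatter), which does not match the step seen with the 4-chloro-3-(trifluoromethyl)phenyl pair: the same change on two cores in this assay, a 2.0-fold higher number (0.30 log units; within the scatter) from compound 1 to compound 3 and a 5.5-fold lower number (0.74 log units; beyond the scatter) from compound 2 to compound 4, 11-fold (1.04 log units) apart, beyond the scatter of two such steps. Both comparisons rest on the same four compounds and so form a single observation seen from two sides, which shows that the step for this change depends on the core here but does not show why, or which of the two steps is the more usual in the series.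

The compounds shown leave open how other groups in place of chloro, such as fluoro or methyl, would behave on each core. They also leave open whether the difference follows the amine or the chain length, a question that a diethylamino group on the chain of compound 3 or a dimethylamino group on the chain of compound 1 would help to separate.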